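This account rests on a few compounds, and the source may have more. Where it says the series, first, only, none or still open, it means among the compounds named here.

Compound 2 `O=C1C=C(N2CCC2)C(=O)c2c1nc1n2[C@H]2OC[C@@H](O)[C@H]2OC1` carries azetidin-1-yl on the shared core; in a functional assay on MCF7 cells (Homo sapiens) for inhibition, read by sulforhodamine B assay (on this read-out lower numbers stand for stronger inhibition and higher numbers for weaker inhibition), compound 2 gives only > 16000 nM, which is a limit of the assay and not a number. Of the three values shown it is the one that sits at the limit of > 16000 nM in this assay, at which 1 of the 3 values shown sits. Compound 4 `Cc1ccc(NC2=CC(=O)c3nc4n(c3C2=O)[C@H]2OC[C@@H](O)[C@H]2OC4)cc1C` differs from compound 2 in one place: (3,4-dimethylphenyl)amino in place of azetidin-1-yl on a double-bonded ring carbon. Among the compounds with values here, no measured step touches this change directly. The nearest comparison is among the arylamino compounds: compound 1 `O=C1C(Nc2ccc(I)cc2)=CC(=O)c2c1nc1n2[C@H]2OC[C@@H](O)[C@H]2OC1` gives 3890 nM in this assay and compound 3 `Cc1ccc(NC2=CC(=O)c3c(nc4n3[C@H]3OC[C@@H](O)[C@H]3OC4)C2=O)cc1C` gives 4950 nM, and a 1.3-fold higher number from compound 1 to compound 3 (0.10 log units; within the scatter). Both arylamino compounds thus sit well inside the measurable range, whereas compound 2 does not. Compound 4 is the regioisomer of compound 3 with the same (3,4-dimethylphenyl)amino group, so it is expected to land near compound 3, and the step is estimated as an at least 3.2-fold lower number from compound 2 to compound 4 (0.50 log units; beyond the scatter), toward stronger inhibition. For compound 4 a value of 5000 nM is expected, with a range from 1800 nM to 14000 nM.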

Compound 4, half-maximal inhibitory concentration: 2080 nM
Compound 4: the middle estimate sits 2.4-fold (0.38 log units) above what was measured, within the range that was stated.
By their numbers in this assay, from the lowest: compounds 4, 1 and 3 (each within the scatter of the next, the first and the last beyond it). At a limit, above all of these: compound 2.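

Within the data shown here, on this double-bonded ring carbon, (3,4-dimethylphenyl)amino in place of azetidin-1-yl gives an at least 7.6-fold lower number from compound 2 to compound 4 (0.88 log units; beyond the scatter) in this assay, the first readable step that exchanges an azetidine for an arylamine rather than one aryl group for another. Compound 2 stands at a limit and not at a number: the limit of > 16000 nM in this assay, at which 1 of the 4 values shown sits. The step is therefore a lower bound on the true size of the change, and it carries the series from that limit into the measurable range.

The change alters ring size, aromatic character and the hydrogen-bond donor count all at once, and the compounds shown cannot separate these. A piperidin-1-yl group or an N-methyl arylamino group at this ring carbon would pull those pieces apart.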